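The compounds below may be only part of what the source reports. "The series", "measured", "known", "first", "only" and "open" are said of these compounds alone.

Compound 1 `CCCn1cc(C(=O)NCc2ccc(OC)cc2)c(=O)c2cc(F)c(N3CCC(C(N)=O)CC3)cc21`: 41400 nM
Compound 2 `CCCCn1cc(C(=O)NCc2ccc([N+](=O)[O-])cc2)c(=O)c2cc(F)c(N3CCC(C(N)=O)CC3)cc21`: > 100000 nM

Both values come from an ADME assay on J774.1 cells (Mus musculus) for cytotoxicity, read by resazurin assay, with a stated time of 48 h; a lower number here means a stronger inhibitor, a higher number a weaker inhibitor. Compound 2 gives > 100000 nM, which is a limit of the assay and not a number. That places compound 2 at the limit of > 100000 nM in this assay, at which 1 of the 2 values shown sits. Compound 1, in contrast, has an exact reading of 41400 nM.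

The next molecule, compound 3 `CCCCn1cc(C(=O)NCc2ccco2)c(=O)c2cc(F)c(N3CCC(C(N)=O)CC3)cc21`, differs from compound 2 in one place: furan-2-yl in place of 4-nitrophenyl on a saturated chain carbon bound to an amide-type nitrogen. Put simply, furan-2-yl stands in place of 4-nitrophenyl on a saturated chain carbon bound to an amide-type nitrogen.

Going by the values given here, no two measured compounds differ in only one place, so no measured step shows how much such a change matters in this assay. Among the compounds with values here, the expectation therefore leans on compound 1 at 41400 nM, the only exact number available. A moderate move toward a lower number, meaning stronger inhibition, is expected, although compound 3 could also reach the limit. The expected change is an at least 2.2-fold lower number from compound 2 to compound 3 (0.34 log units; beyond the scatter). For compound 3 the estimated value is 45000 nM, with an expected range of 18000 nM to 100000 nM.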

Compound 3, half-maximal inhibitory concentration in the J774.1 assay: 41400 nM
Compound 3: the middle estimate sits 1.1-fold (0.04 log units) above what was measured; low and high end bracket the measured number.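

Going by these compounds alone, in the J774.1 assay, replacing 4-nitrophenyl with furan-2-yl gives an at least 2.4-fold lower number from compound 2 to compound 3 (0.38 log units; beyond the scatter), the first single-place comparison in this set, and it shows that the reading responds to a change at this position. From the compounds shown here alone, the true size of the step stays unknown, since compound 2 sits at a limit of the assay and not at a number: the limit of > 100000 nM in the J774.1 assay, at which 1 of the 3 values shown sits. In a physicochemical assay for lipophilicity, read by HPLC (a higher number here means a more lipophilic compound, a lower number a more polar compound), compound 2 gives 2.4 and compound 3 gives 2.4; the same change gives no change at the digits printed from compound 2 to compound 3 (within the scatter), so the shift in the J774.1 assay comes with no measurable shift in the physicochemical assay.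

This single pair cannot say whether the gain in cell toxicity follows from having furan-2-yl in this place or from losing 4-nitrophenyl, and compound 1 differs from both compounds in more than one place, so it offers no direct comparison. An unsubstituted phenyl ring or a 4-aminophenyl group in the same place, on the same butyl-bearing core, would help separate the effect of the ring from that of its nitro group.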